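This account rests on a few compounds, and the source may have more. Where it says the series, first, only, none or still open, it means among the compounds named here.

- compound 1 `C=C1CC[C@@H]2[C@](C)(COC(=O)c3cccnc3)[C@H](O)CC[C@@]2(C)[C@@H]1C/C=C1\C=COC1=O` gives 2050000 nM
- compound 2 `C=C1CC[C@@H]2[C@](C)(COC(C)=O)[C@H](O)CC[C@@]2(C)[C@@H]1C/C=C1\C=COC1=O` gives 334000 nM

Among the compounds with values here, in an ADME assay on HepG2 2.2.15 cells (Homo sapiens) for cytotoxicity, read by MTT assay (on this read-out higher numbers stand for lower toxicity in this test and lower numbers for higher toxicity in this test), compound 2 holds the lower of the two numbers, and compound 1 is its only neighbour. Next in the series is compound 3 `C=C1CC[C@@H]2[C@](C)(COC(=O)CCCC)[C@H](O)CC[C@@]2(C)[C@@H]1C/C=C1\C=COC1=O`, which differs from compound 2 by propyl in place of hydrogen on a saturated chain carbon bound to a carbonyl carbon. The same difference reads methyl to butyl. Within the data shown here, one measured step bears on this, and only loosely: a 6.1-fold lower number from compound 1 to compound 2 (0.79 log units; beyond the scatter), also a change on a carbonyl carbon, but between pyridin-3-yl and methyl. Among the measured compounds shown here, no measured compound carries a longer chain, so the direction remains open and no step beyond the scatter is expected in this assay. The estimate amounts to a 1.1-fold lower number from compound 2 to compound 3 (0.05 log units; within the scatter), which is expected to lie within the scatter. Compound 3 is expected at 300000 nM, with an estimated range of 120000 nM to 800000 nM.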

Compound 3, half-maximal cytotoxic concentration: 225000 nM
Estimate against measurement, compound 3: 1.3-fold (0.12 log units) above; the measured number falls inside the stated range.
By their numbers in this assay, from the lowest: compounds 3 and 2 (each within the scatter of the next); then compound 1.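

In this assay, propyl in place of hydrogen on a saturated chain carbon bound to a carbonyl carbon gives only a small shift (a 1.5-fold lower number from compound 2 to compound 3 (0.17 log units; within the scatter)), so on this evidence methyl and butyl on the carbonyl carbon are not told apart. Set against pyridin-3-yl, butyl gives a step of similar kind to the earlier one with methyl (a 9.1-fold lower number from compound 1 to compound 3 (0.96 log units; beyond the scatter)), so compound 1 now stands apart from two saturated chains, not from one. Nothing available explains this separation.

On these data alone, whether a longer chain such as octyl would stay within the scatter of compound 3 remains open. Also open, as far as these compounds go, is whether a phenyl ring or an amine on the carbonyl carbon would read like pyridin-3-yl or like the saturated chains.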